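Adding a Chloro Group to Compound 1

The compounds below may be only part of what the source reports. "The series", "measured", "known", "first", "only" and "open" are said of these compounds alone.

Compound 1, with the structure `COc1ccc(OC)c(CNC(=O)NS(=O)(=O)c2ccccc2)c1`, was tested in a functional assay on thoracic aorta (Rattus norvegicus, strain Wistar), with a stated time of 15 min; on this read-out lower numbers stand for an effect already at smaller amounts and higher numbers for an effect only at larger amounts of compound. In this assay compound 1 gives only a limit, > 300000 nM, and not a number. Two other compounds were measured alongside it. Compound 3, `CC(NC(=O)NS(=O)(=O)c1ccccc1)c1ccccc1OCc1ccccc1`, also reaches only a limit, giving > 200000 nM in this assay. Going by the values given here, compound 2, `COc1ccc(F)cc1C(C)NC(=O)N(C)S(=O)(=O)c1ccc(Cl)cc1`, is the one compound of the three with a real number, giving 12600 nM in this assay. Among the compounds with values here, compound 2 differs from compound 1 in more than one place, so the two values show only that compound 2 gives a number where compound 1 gives a limit, and no single cause can be drawn from that.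

Compound 4, `COc1ccc(OC)c(CNC(=O)NS(=O)(=O)c2ccc(Cl)cc2)c1`, has not yet been measured. It differs from compound 1 by one change, (chloro in place of hydrogen on an aromatic carbon). Within the data shown here, no step between two measured compounds that differ in one place is available, so nothing measured tells what this change does. Since compound 1 sits at a limit, the expected step in this assay is an at least 1.5-fold lower number from compound 1 to compound 4 (0.17 log units; that floor lies within the scatter), which is small and may well end at a limit again. The estimated value of compound 4 in this assay is 200000 nM, with an expected range from 50000 nM to 600000 nM.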

Compound 4, half-maximal effective concentration: > 300000 nM
Compound 4 was reported as a limit (the forecaster's own chance of this, stated with the estimate: 60%); at least 1.5-fold (0.17 log units) between middle value and limit.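

Compound 1 and compound 4 both end at the same limit in this assay rather than at a number, so no step between them can be read: the limit of > 300000 nM in this assay, at which 2 of the 4 values shown sit.

The compounds shown leave open what chloro in place of hydrogen does in this assay, and which of the differences in compound 2 goes with its real number.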